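Swapping the amide substituent from benzyl to thiazolyl

The source may hold more compounds than are shown below. What is called first, only, known or untested is meant among the compounds shown, and "the series" means these compounds.

Measured so far:
compound 1 `COc1cc2nc(C)cc(OCC(=O)Nc3cc(C)cc(C)c3)c2cc1OC`: 4.84
compound 2 `COc1ccc2nc(C)cc(OCC(=O)NCc3cc(C)cc(C)c3)c2c1`: 5.25

In a physicochemical assay for lipophilicity, read by HPLC, in phosphate buffer, measured as chromatographic lipophilicity, at pH 7.4 (a higher number here means a more lipophilic compound, a lower number a more polar compound), compound 2 gives 5.25, the higher of the two numbers; compound 1 sits lower, beyond the usual scatter. Compound 3 `COc1ccc2nc(C)cc(OCC(=O)Nc3nc(C)c(C)s3)c2c1` differs from compound 2 in one place: 4,5-dimethyl-1,3-thiazol-2-yl in place of 3,5-dimethylbenzyl on an amide-type nitrogen. Among the measured compounds shown here, no measured pair shows this kind of swap, so the expectation rests on what enters and leaves. A step downward in this assay is expected, of size a number 1.05 log units lower from compound 2 to compound 3 (beyond the scatter), clearly beyond the scatter. Compound 3 is therefore estimated at 4.2, with a likely range from 3.6 to 4.8.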

Compound 3, distribution coefficient: 4.24
Estimate against measurement, compound 3: 0.04 log units below; the measured number falls inside the stated range.
By their numbers in this assay, from the lowest: compound 3; then compound 1; then compound 2.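

The reading in this assay shows a number 1.01 log units lower from compound 2 to compound 3 (beyond the scatter) with only the group on the amide-type nitrogen changed, so a change at this position alone can move the number well beyond the scatter. The two groups differ in ring, atoms and hydrogen-bond acceptors all at once, and this single step does not separate those differences. Nothing available explains the drop.

Still open, from the compounds shown here alone, is how a pyridyl ring or a chain ending in an amine would read on the same nitrogen. Also open, going by these compounds, is whether a step of this size would hold on the core of compound 1.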